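Swapping an Acetamide for a Pyrrolidine on the Side Chain

The source may hold more compounds than are shown below. What is called first, only, known or untested is meant among the compounds shown, and "the series" means these compounds.

Of the compounds shown here, three built on one shared core have been tested in an assay on FRT cells with Cystic fibrosis transmembrane conductance regulator variant F508del (Homo sapiens) as the target, read by fluorescence, with a stated time of 25 min; on this read-out lower numbers stand for an effect already at smaller amounts and higher numbers for an effect only at larger amounts of compound. Compound 1 `CN(C)CCN1CCN(c2nc(-c3ccccn3)nc3c2CN(Cc2ccccc2)CC3)CC1` gives 1500 nM. Compound 2 `COc1ccc(CN2CCc3nc(-c4ccccn4)nc(NCCCn4ccnc4)c3C2)cc1` gives 200 nM, and compound 3 `CC(=O)NCCNc1nc(-c2ccccn2)nc2c1CN(Cc1ccc(F)cc1)CC2` gives 200 nM. Compound 3 therefore sits level with compound 2 within the scatter of the method, and the two together mark the lowest numbers of the three, while compound 1 lies well above them by a margin that exceeds the scatter.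

Compound 4 `Fc1ccc(CN2CCc3nc(-c4ccccn4)nc(NCCN4CCCC4)c3C2)cc1` has not been measured. It is derived from compound 3 by one change: pyrrolidin-1-yl in place of acetamido on a saturated chain carbon, two bonds along the chain from a nitrogen on an aromatic ring. For the measured compounds named here, no pair of measured compounds shows this exact change, so its effect has to be judged from what is known. Compound 2 and compound 3 carry quite different chains on the same nitrogen of the core and yet land on the same number, which suggests the chain end is not decisive here. A step of modest size, not clearly beyond the scatter in either direction, is therefore expected in this assay, namely a 1.5-fold higher number from compound 3 to compound 4 (0.18 log units; within the scatter). On that basis compound 4 is estimated at 300 nM, with a likely range from 100 nM to 1000 nM.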

Compound 4, half-maximal effective concentration in the Cystic fibrosis transmembrane conductance regulator assay: 200 nM
For compound 4 the middle estimate is 1.5-fold (0.18 log units) above the measured one, and the stated range covers the measured number.
By their numbers in the Cystic fibrosis transmembrane conductance regulator assay, from the lowest: compounds 2, 3 and 4 (each within the scatter of the next); then compound 1.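

In the Cystic fibrosis transmembrane conductance regulator assay compound 3 gives 200 nM and compound 4 gives 200 nM. In the Cystic fibrosis transmembrane conductance regulator assay, putting pyrrolidin-1-yl in place of acetamido on a saturated chain carbon, two bonds along the chain from a nitrogen on an aromatic ring, gives no change at the digits printed from compound 3 to compound 4 (within the scatter). For the compounds shown here, this is the first direct comparison at this position, and it shows that the end of the chain can be rebuilt without a change beyond the scatter, even though acetamido has 1 hydrogen-bond donor and a double bond outside aromatic rings, while pyrrolidin-1-yl has 0 hydrogen-bond donors and a five-membered non-aromatic ring. In a physicochemical assay for solubility, read by HPLC, with a stated time of 24 h, at pH 7.4, tested at 250 uM (on this read-out higher numbers stand for higher solubility and lower numbers for lower solubility), compound 3 gives 226000 nM and compound 4 gives 196000 nM. The same exchange in the physicochemical assay gives a 1.2-fold lower number from compound 3 to compound 4 (0.06 log units; within the scatter), so this pair is not separated on either read-out, and no measurement at hand accounts for the result.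

One pair cannot settle whether other groups at this chain end, such as a carboxylic acid or a morpholine ring, would give a similar number. From the compounds shown here alone, it also remains open whether the same exchange would read alike with a different group elsewhere on the shared core.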